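Removing trifluoromethyl from compound 3

This account rests on a few compounds, and the source may have more. Where it says the series, first, only, none or still open, it means among the compounds named here.

In a functional assay on KG-1 cells (Homo sapiens) for cytotoxicity, read by luminescence and CellTiter-Glo, with a stated time of 3 days (a higher number here means a weaker inhibitor, a lower number a stronger inhibitor), compound 3 `N#Cc1ccc(NC(=O)c2cc(C(F)(F)F)ccc2O)cc1` gives 4810 nM and lies within the scatter of compound 1 `N#Cc1ccc(NC(=O)c2cccc(Br)c2O)cc1` at 3260 nM in the same read-out. Compound 2 `COc1cccc(C(=O)Nc2ccc(C#N)cc2)c1O` gives > 10000 nM as a limit of the assay and not a number. Compound 4 `N#Cc1ccc(NC(=O)c2ccccc2O)cc1` carries hydrogen in place of trifluoromethyl on an aromatic carbon, para to a hydroxy group (hydrogen in place of trifluoromethyl on an aromatic carbon). Among the compounds with values here, no measured step makes this exchange. Within the data shown here, the only measured step, methoxy in place of bromo, gives an at least 3.0-fold higher number from compound 1 to compound 2 (0.48 log units; beyond the scatter) and lies beyond the scatter, so one exchange of substituent can matter in this assay for this series. A small step is therefore expected, estimated as a 1.9-fold higher number from compound 3 to compound 4 (0.27 log units; within the scatter) towards a higher number. For compound 4 the estimated value is 9000 nM with an expected range of 3500 nM to 20000 nM in this series.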

Compound 4, half-maximal inhibitory concentration: 5370 nM
Estimate against measurement, compound 4: 1.7-fold (0.22 log units) above; measured number inside the range.
By their numbers in this assay, from the lowest: compounds 1, 3 and 4 (each within the scatter of the next). At a limit, above all of these: compound 2.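

At the carbon para to a hydroxy group, hydrogen in place of trifluoromethyl gives a 1.1-fold higher number from compound 3 to compound 4 (0.05 log units; within the scatter) in this assay, so trifluoromethyl at this place is not required for the activity seen. Bromo is likewise dispensable, with a 1.6-fold higher number from compound 1 to compound 4 (0.22 log units; within the scatter) in this assay. Compound 2 carries a limit of the assay and not a number, so an at least 1.8-fold lower number from compound 2 to compound 4 (0.27 log units; that floor lies within the scatter) gives only a floor: the limit of > 10000 nM in this assay, at which 1 of the 4 values shown sits.

As far as these compounds go, whether an amine or a carboxylic acid at this carbon would shift the number beyond the scatter stays open. So does the true size of the methoxy step.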